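Three Limits and One Unmeasured Chain End

The source may hold more compounds than are shown below. What is called first, only, known or untested is meant among the compounds shown, and "the series" means these compounds.

In a functional assay on Jurkat cells (Homo sapiens) for cytotoxicity, with a stated time of 72 h (on this read-out higher numbers stand for an effect only at larger amounts of compound and lower numbers for an effect already at smaller amounts), compound 1 `C=C[C@@](C)(/C=C/c1ccc(O)cc1)CCCO` gives > 49000 nM, which is a limit and not a number. Compound 2 `C=C[C@@](C)(/C=C/c1ccc(O)cc1)CC/C=C/C(=O)OCC` gives > 49000 nM, again a limit. Compound 3 `C=C[C@@](C)(/C=C/c1ccc(O)cc1)CC/C=C/C#N` gives > 49000 nM, also a limit. Compound 3 therefore has no number of its own, and the series offers only (the limit of > 49000 nM in this assay, at which 3 of the 3 values shown sit).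

Compound 4 `C=C[C@@](C)(/C=C/c1ccc(O)cc1)CC/C=C(C)/C=N/N` has not yet been measured. Its difference from compound 3 is a group of 6 heavy atoms (4 carbon, 2 nitrogen; no ring) in place of a group of 4 heavy atoms (3 carbon, 1 nitrogen; no ring), on a saturated chain carbon, three bonds along the chain from two double-bonded chain carbons. The group that leaves is 2-cyanoethenyl, and the group that enters has no common name.

Going by the values given here, three measured steps concern this same end of the chain: a step that the two limits leave unreadable from compound 1 to compound 2, a step that the two limits leave unreadable from compound 1 to compound 3 and a step that the two limits leave unreadable from compound 2 to compound 3. None of them has a readable size, so they indicate no direction and no scale for the new change. Another limit is the most likely result in this assay, and no clear shift is expected. The expected change is an at least 1.0-fold lower number from compound 3 to compound 4 (0.03 log units; that floor lies within the scatter). Compound 4 is estimated at 45000 nM, with an expected range from 18000 nM to 60000 nM.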

Compound 4, half-maximal effective concentration: > 49000 nM
Compound 4: only a limit was reported (the forecaster's own chance of this, stated with the estimate: 70%); middle value at least 1.0-fold (0.03 log units) from the limit.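

In this assay compound 4 gives > 49000 nM, again a limit and not a number, so no step to compound 4 from compound 1, compound 2 or compound 3 can be read: the limit of > 49000 nM in this assay, at which 4 of the 4 values shown sit.

The compounds shown leave open whether any group at this chain end would give a measurable value in this assay.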